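The source may report more compounds than this note shows. Statements on the series, on what has been measured and on what is new or still open speak of the compounds shown alone.

Of the compounds shown here, three have been measured in a functional assay on the whole organism (strain Wistar albino) for inhibition, with Rattus norvegicus as the target, read by paw edema, with stated times of 1 h and 2 h, at a dose of 0.32 mmol/kg by the intraperitoneal route (a higher number here means more inhibition at the dose given (going by the name of the read-out), a lower number less inhibition), so far. Compound 1 `COc1ccc(-c2nn(-c3ccc(S(N)(=O)=O)cc3)cc2/C=N\c2ccc(Cl)cc2)cc1` gives 63%, compound 2 `Cc1ccc(-c2nn(-c3ccc(Cl)cc3)cc2/C=C\C(=O)c2ccc(Cl)cc2)cc1` gives 49.2%, and compound 3 `COc1ccc(C(=O)C(CC(=O)c2ccc(Cl)cc2)c2cn(-c3ccc(Cl)cc3)nc2-c2ccc(C)cc2)cc1` gives 16.1%. Compound 3 therefore stands lowest of the three numbers: compound 2 is its nearest neighbour, yet its value lies above that of compound 3 by a gap beyond the usual scatter, and compound 1 lies further above still, again beyond the scatter.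

From compound 3 the account moves to compound 4 `COc1ccc(C(=O)C(CC(=O)c2ccc(Cl)cc2)c2cn(-c3ccc(Cl)cc3)nc2-c2ccc(OC)cc2)cc1`, which has not yet been measured in this assay. The two structures differ in one place: methoxy in place of methyl on an aromatic carbon. Cut one bond further out, the change reads 4-methylphenyl to 4-methoxyphenyl. For the measured compounds named here, no pair among the measured compounds shows this change, so there is no measured step to draw on. The expected step, a number 3.9 percentage points higher from compound 3 to compound 4 (within the scatter), is small, with no direction that would exceed the scatter. Compound 4 is estimated at 20%, within a range from 8% to 34%.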

Compound 4, a percentage reported as inhibition, in the whole organism at one dose (the size of the read-out at that dose, not a potency): 0%
Estimate against measurement, compound 4: 20 percentage points above; the measured number lies below the stated range.
By their numbers in this assay, from the lowest: compound 4; then compound 3; then compound 2; then compound 1.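

In this assay, for the compounds shown here, the change from 4-methylphenyl to 4-methoxyphenyl gives a number 16.1 percentage points lower from compound 3 to compound 4 (beyond the scatter) and so shows, as no earlier pair could, that this place, on an aromatic carbon para to a large group, responds to the exchange of methyl for methoxy. The modest inhibition of compound 3 is lost altogether in compound 4, which reads 0% at the dose given. Nothing available explains this step.

The compounds shown leave open whether the same exchange has a similar effect on the cores of compound 1 and compound 2, as this single pair is the only view of it. They also hold no hydroxyl, amine or ethoxy group at this place, so how any such group would compare with methyl and methoxy remains an open question.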